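The compounds below may be only part of what the source reports. "The series", "measured", "known", "first", "only" and "open" are said of these compounds alone.

Compound 1 `CCCCCCCC(CCO)n1cnc2c(Cl)nc(F)nc21` and compound 2 `CCCCCCCCC(CCO)n1cnc2c(Cl)nc(F)nc21` share one core, while compound 3 `CCCCCCCC[C@H](CCO)n1cnc2c(Cl)ncnc21` and compound 4 `CCCCCCCCC[C@H](CCO)n1cnc2c(Cl)ncnc21` share another; the difference between the two cores is not broken down here. In a functional assay on SW480 cells (Homo sapiens) for antiproliferative activity, read by MTT assay, with a stated time of 48 h (a higher number here means a weaker inhibitor, a lower number a stronger inhibitor), compound 1 gives 26100 nM, and compound 2 gives 15000 nM. The change between them is methyl in place of hydrogen on a saturated chain carbon, eight bonds along the chain from an aromatic nitrogen, and it made a 1.7-fold lower number from compound 1 to compound 2 (0.24 log units; within the scatter). In this assay compound 3 gives 320 nM, the lowest of the three numbers, beyond the scatter from both of the others. Compound 4 differs from compound 3 by methyl in place of hydrogen on a saturated chain carbon, nine bonds along the chain from an aromatic nitrogen; this is the same kind of change as that between compound 1 and compound 2, but it sits nine rather than eight bonds along the chain from an aromatic nitrogen. Compound 4 is expected to lie close to compound 3 in this assay, because the earlier step of a 1.7-fold lower number from compound 1 to compound 2 (0.24 log units; within the scatter) stayed within the scatter. For compound 4 the expected step is a 1.3-fold lower number from compound 3 to compound 4 (0.11 log units; within the scatter). Compound 4 is therefore estimated at 250 nM, with a likely range from 110 nM to 600 nM.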

Compound 4, half-maximal inhibitory concentration: 1630 nM
Compound 4: middle estimate off by 6.5-fold (0.81 log units), on the low side, and the stated range ends below it.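

On the core of compound 3, the added methyl moved the number in this assay clearly: a 5.1-fold higher number from compound 3 to compound 4 (0.71 log units; beyond the scatter). Set beside the earlier step, the same change did not carry over from one core to the other in this assay: the same change on two cores in this assay, a 1.7-fold lower number (0.24 log units; within the scatter) from compound 1 to compound 2 and a 5.1-fold higher number (0.71 log units; beyond the scatter) from compound 3 to compound 4, 8.9-fold (0.95 log units) apart, beyond the scatter of two such steps. This shows that, for these two pairs, the step measured on the core of compound 1 was no reliable guide to the step on the core of compound 3, though it does not show which difference between the cores is responsible, and one pair on each core gives no general rule for the series.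

The compounds shown leave open whether a longer chain on the core of compound 3 would continue the same trend or reverse it. They also leave open whether a chain carrying an amine or a carboxylic acid would show the same dependence on the core.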